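Swapping a Methylphenyl for a Dichlorophenyl Group

A few compounds are considered here, and "the series" means these few. Any claim that something is new, unique, unknown or untested is made for them only; others in the source may bear on it.

Of the compounds shown here, three built on one shared core have been tested in a functional assay on NCI-H1975 cells (Homo sapiens) for inhibition, read by MTT assay, with a stated time of 72 h; on this read-out lower numbers stand for stronger inhibition and higher numbers for weaker inhibition. Compound 1 `O=C(CSc1nc(Nc2ccccc2)c2ccccc2n1)Nc1cccc(Cl)c1` gives 8460 nM. Compound 2 `O=C(CSc1nc(Nc2ccccc2)c2ccccc2n1)Nc1ccc(Cl)cc1Cl` gives 8410 nM, so the step is a 1.0-fold lower number from compound 1 to compound 2 (0.00 log units; within the scatter). Compound 3 `C=CC(=O)Nc1cccc(NC(=O)CSc2nc(Nc3ccccc3C)c3ccccc3n2)c1` gives 9920 nM, the highest of the three numbers, though its gaps to compound 1 and to compound 2 both lie within the scatter. Compound 4 `C=CC(=O)Nc1cccc(NC(=O)CSc2nc(Nc3ccc(Cl)cc3Cl)c3ccccc3n2)c1` has not yet been measured. It differs from compound 3 in one place: 2,4-dichlorophenyl in place of 2-methylphenyl on a nitrogen on an aromatic ring. Within the data shown here, the only measured step, from compound 1 to compound 2, brought 2,4-dichlorophenyl onto an amide-type nitrogen rather than onto a nitrogen on an aromatic ring, and left the number unchanged; no step touches the nitrogen changed here. For compound 4 in this assay no step beyond the scatter is expected, a 1.1-fold lower number from compound 3 to compound 4 (0.04 log units; within the scatter). Compound 4 is estimated at 9000 nM, within 4000 nM to 20000 nM.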

Compound 4, half-maximal inhibitory concentration: 5990 nM
Beside the measured number, compound 4's estimate is 1.5-fold (0.18 log units) above it, within the range that was stated.
By their numbers in this assay, from the lowest: compounds 4, 2, 1 and 3 (each within the scatter of the next).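

The first step read at this nitrogen, a 1.7-fold lower number from compound 3 to compound 4 (0.22 log units; within the scatter), shows that 2,4-dichlorophenyl in place of 2-methylphenyl does not move the number in this assay beyond the scatter. So two differently substituted phenyl groups on this nitrogen cannot be told apart here, though this rests on a single pair of compounds. Nothing available here accounts for the step or links it to any feature of either group. Still open, going by these compounds, is whether a group of another kind on this nitrogen, such as a chain carrying an amine or a carboxylic acid, would shift the number beyond the scatter.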